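The source may hold more compounds than are shown below. What is called first, only, known or untested is meant among the compounds shown, and "the series" means these compounds.

In a functional assay for agonist activity at G protein-coupled receptor 88 (Homo sapiens), read by HTRF and cAMP accumulation (on this read-out higher numbers stand for an effect only at larger amounts of compound and lower numbers for an effect already at smaller amounts), three compounds have been measured so far. Compound 1 `CC(C)C[C@H](N)CN(C(=O)[C@@H]1C[C@H]1c1ccccc1)c1ccc(-c2ccccc2)cc1` gives 880 nM. Among the compounds with values here, compound 2 `CC(C)(N)CN(C(=O)[C@@H]1C[C@H]1c1ccccc1)c1ccc(-c2ccccc2)cc1` gives 1.4 nM, and the single change between the two, a 630-fold lower number from compound 1 to compound 2 (2.80 log units; beyond the scatter), is the only one-place step in the set. Compound 3 `CC[C@H](C)[C@H](N)CN(C(=O)[C@@H]1C[C@H]1c1cccc(C)c1)c1ccc(-c2ccccc2)cc1` gives 1200 nM, the highest of the three numbers; its value and that of compound 1 lie within the usual scatter of each other, while compound 2 lies far below both.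

Compound 4 `CC[C@H](C)[C@H](N)CN(C(=O)[C@@H]1C[C@H]1c1ccncc1)c1ccc(-c2ccccc2)cc1` differs from compound 3 in one place: pyridin-4-yl in place of 3-methylphenyl on a saturated ring carbon. Within the data shown here, no measured step touches this position. Among the measured compounds shown here, the one step known concerns the amino chain bound to the amide-type nitrogen and gives no guide to what exchanging 3-methylphenyl for pyridin-4-yl on the three-membered ring does. With nothing pointing either way, the expectation is a step within the scatter, a 1.3-fold higher number from compound 3 to compound 4 (0.10 log units; within the scatter), in no particular direction. The starting point is compound 3, which gives 1200 nM. Compound 4 is therefore expected to give about 1500 nM, with a range from 400 nM to 6000 nM.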

Compound 4, half-maximal effective concentration: 1500 nM
Compound 4: middle estimate and measured number agree at the digits printed; the range from low to high includes it.
By their numbers in this assay, from the lowest: compound 2; then compounds 1, 3 and 4 (each within the scatter of the next).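

In this assay, the position on the saturated ring carbon of the three-membered ring now has its first measured step: pyridin-4-yl in place of 3-methylphenyl gives a 1.3-fold higher number from compound 3 to compound 4 (0.10 log units; within the scatter). This exchange replaces a ring of carbon only with a six-membered aromatic ring holding one hetero atom, and it adds a hydrogen-bond acceptor, yet the two numbers cannot be told apart, so with the amino chain of compound 3 kept in place these differences leave no visible mark on this read-out. Nothing available here explains why the step is so small.

As far as these compounds go, compounds 3 and 4 both sit far above compound 2, so it remains open whether the same exchange would also stay within the scatter when made on compound 2, with its 1-amino-1-methylethyl chain, where a shift might show more clearly. Also open, from the compounds shown here alone, is how other groups on that ring carbon, such as pyridin-2-yl, 4-fluorophenyl or a carboxylic acid, would read in this assay.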